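The source may report more compounds than this note shows. Statements on the series, on what has been measured and on what is new or still open speak of the compounds shown alone.

Three compounds sharing a core have been taken to a toxicity assay on HepG2 cells (Homo sapiens) for cytotoxicity, read by CellTiter-Glo, with a stated time of 72 h; a lower number here means that less compound is tolerated, a higher number that more compound is tolerated. Compound 1 `COc1ccc(C(F)(F)F)cc1CN(C)C(c1cccnc1)c1nnnn1-c1ccccc1C` has yielded no usable figure there, its entries reading "nd" (no result reported); "nd" (no result reported); "nd" (no result reported) (3 entries). Compound 2 `CC(=O)N(Cc1cc(C(F)(F)F)ccc1F)C(c1cncnc1)c1nnnn1-c1ccccc1C` returned only a limit of the assay, > 30000 nM. For the measured compounds named here, compound 3 `CCCN(C(c1cncnc1)c1nnnn1-c1ccccc1C)C1(c2cccc(C(F)(F)F)c2)CC1` gave 13000 nM, the only true number in the set, so there is no other number to rank it against.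

Compound 4 `CCCN(C(c1cccnc1)c1nnnn1-c1ccccc1C)C1(c2cccc(C(F)(F)F)c2)CC1` differs from compound 3 by one exchange: pyridin-3-yl in place of pyrimidin-5-yl on a saturated chain carbon bound to an amine nitrogen and an aromatic carbon. Going by the values given here, compound 1 also carries pyridin-3-yl, but no measured step shows what this exchange does in this assay. The expectation therefore stays modest and starts from compound 3 at 13000 nM: a small shift towards lower numbers, meaning slightly less compound tolerated, and probably one that stays within the usual scatter. The estimated change is a 1.4-fold lower number from compound 3 to compound 4 (0.16 log units; within the scatter). For compound 4 the expected half-maximal cytotoxic concentration is 9000 nM, with an estimated range of 4000 nM to 22000 nM.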

Compound 4, half-maximal cytotoxic concentration: 10000 nM
Compound 4: middle estimate off by 1.1-fold (0.05 log units), on the low side; the range from low to high includes it.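

The exchange of pyrimidin-5-yl for pyridin-3-yl, on a saturated chain carbon bound to an amine nitrogen and an aromatic carbon, now has a measured step in this assay: a 1.3-fold lower number from compound 3 to compound 4 (0.11 log units; within the scatter). For the compounds shown here, at this position, then, the pair gives no difference that can be told from the usual scatter, something the earlier compounds could not show, as no step linked any two of them. Compound 2 remains a limit of the assay and not a number, the only such reading among the compounds shown: the limit of > 30000 nM in this assay, at which 1 of the 4 values shown sits.

What the compounds shown leave open is how a plain phenyl ring, or a ring carrying a carboxylic acid, would read on that same saturated chain carbon in this assay. Also open, going by these compounds, is whether the exchange of pyrimidin-5-yl for pyridin-3-yl would give a similarly small step with a different group on the amine nitrogen, such as a longer chain, since this single pair is the only place where it can be read.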